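Swapping the side group on a shared core: compound 4

A few compounds are considered here, and "the series" means these few. Any claim that something is new, unique, unknown or untested is made for them only; others in the source may bear on it.

Measured compounds:
- Compound 1 `CC(C)C(c1ccc(-c2ccc3cccc(F)c3c2)[nH]c1=O)N1CCCCS1(=O)=O` gives 14 nM in an assay on CHO cells for displacement of a labelled ligand from prostaglandin E2 receptor EP3 subtype (Homo sapiens), read by radioligand binding; on this read-out lower numbers stand for stronger inhibition and higher numbers for weaker inhibition.
- Compound 2 `CC(C)C(Cc1nnc[nH]1)c1ccc(-c2ccc3cccc(F)c3c2)[nH]c1=O` gives 10 nM.
- Compound 3 `CC(C)C(Nc1nccs1)c1ccc(-c2ccc3cccc(F)c3c2)[nH]c1=O` gives 9.4 nM.

All three compounds share the same core and differ only in the group attached to a saturated chain carbon bound to an aromatic carbon and a saturated chain carbon. Compound 3 has the lowest of the three numbers, but the steps of a 1.1-fold lower number from compound 2 to compound 3 (0.03 log units; within the scatter) and a 1.5-fold lower number from compound 1 to compound 3 (0.17 log units; within the scatter) both lie within the scatter, so the three values are indistinguishable within the scatter. The step of a 1.4-fold lower number from compound 1 to compound 2 (0.15 log units; within the scatter) tells the same story: three quite different groups at this position have left the number essentially unchanged.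

Compound 4 `CC(C)C(c1ccc(-c2ccc3cccc(F)c3c2)[nH]c1=O)N1CCNC1=O` continues this series with 2-oxoimidazolidin-1-yl in place of (1,3-thiazol-2-yl)amino on a saturated chain carbon bound to an aromatic carbon and a saturated chain carbon. Since every measured exchange at this position stayed within the scatter, the same is expected here: no step beyond the scatter, in either direction. The expected step is a 1.3-fold higher number from compound 3 to compound 4 (0.11 log units; within the scatter). Compound 4 is therefore estimated to give about 12 nM, with a range from 5 nM to 30 nM.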

Compound 4, inhibition constant: 9.1 nM
The estimate for compound 4 lay 1.3-fold (0.12 log units) above the measured number; measured number inside the range.
By their numbers in this assay, from the lowest: compounds 4, 3, 2 and 1 (each within the scatter of the next).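

With 2-oxoimidazolidin-1-yl at this position, this assay shows a 1.0-fold lower number from compound 3 to compound 4 (0.01 log units; within the scatter), so a five-membered ring at this site need not be aromatic, as it is in compound 2 and compound 3. The comparisons with the other two compounds, a 1.1-fold lower number from compound 2 to compound 4 (0.04 log units; within the scatter) and a 1.5-fold lower number from compound 1 to compound 4 (0.19 log units; within the scatter), also stay within the scatter, which makes all four groups indistinguishable on this read-out even though the new group brings a carbonyl and fewer hydrogen-bond acceptors than (1,3-thiazol-2-yl)amino. No measurement available here explains why such different groups give such similar numbers.

Every group shown on this saturated chain carbon contains a ring, so it remains open whether a simple amine, a carboxylic acid or a plain longer alkyl chain without any ring would leave the number just as unchanged. Going by these compounds, it is also open whether a much larger group, such as one carrying a second ring, would finally produce a step beyond the scatter, and thereby show where the tolerance of this position ends.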